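A few compounds are considered here, and "the series" means these few. Any claim that something is new, unique, unknown or untested is made for them only; others in the source may bear on it.

Compound 1 `C[C@H](NC(=O)[C@H](N)CC(=O)OCc1ccccc1)C(=O)O` gives 3.52 h in an ADME assay on a cell-free system (plasma, Homo sapiens) for metabolic stability; on this read-out lower numbers stand for a shorter-lived compound and higher numbers for a longer-lived compound.
Compound 2 `C[C@H](NC(=O)[C@H](N)CC(=O)OCc1ccc(F)cc1)C(=O)O` gives 4.33 h in this assay.
Compound 3 `C[C@H](NC(=O)[C@H](N)CCC(=O)OCc1ccccc1)C(=O)O` gives 2.63 h in this assay.

Compound 4 `C[C@H](NC(=O)[C@H](N)CCC(=O)OCc1ccc(F)cc1)C(=O)O` has not yet been measured in this assay. It differs from compound 3 by fluoro in place of hydrogen on an aromatic carbon. The same change, (fluoro in place of hydrogen on an aromatic carbon), separates compound 1 from compound 2, and there it made a 1.2-fold higher number from compound 1 to compound 2 (0.09 log units; within the scatter). The place of the change reads the same in both pairs, so it is the same change; the difference between the core of compound 1 and the core of compound 3 is not broken down here. Compound 3 and compound 1 give numbers within the usual scatter of each other, as do compound 3 and compound 2. For compound 4 a step of similar size is expected, a 1.2-fold higher number from compound 3 to compound 4 (0.07 log units; within the scatter), because a 1.2-fold higher number from compound 1 to compound 2 (0.09 log units; within the scatter) stayed within the scatter. Compound 4 is therefore estimated at 3.1 h in this assay, between 1.8 h and 5.5 h.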

Compound 4, half-life: 2 h
Compound 4: the middle estimate sits 1.6-fold (0.19 log units) above what was measured, and the stated range covers the measured number.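

In this assay, the phenyl to 4-fluorophenyl change gives a 1.3-fold lower number from compound 3 to compound 4 (0.12 log units; within the scatter), so on this core too the step stays small. Set beside the earlier step, it does not differ beyond what repeated measurement allows: the same change on two cores in this assay, a 1.2-fold higher number (0.09 log units; within the scatter) from compound 1 to compound 2 and a 1.3-fold lower number (0.12 log units; within the scatter) from compound 3 to compound 4, 1.6-fold (0.21 log units) apart, within the scatter of two such steps. On these two cores, the change carries over as a step too small to read, with no direction to be taken from either pair, but this does not show that it would behave alike on any further core.

The compounds shown hold only fluoro on the aromatic ring, so the effect of a chloro, methoxy or trifluoromethyl group there remains open. As far as these compounds go, a longer chain in the core also remains open, as does whether any of these groups would give a step beyond the scatter.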